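Cyano to Acetyl on a Phenyl Substituent

A few compounds are considered here, and "the series" means these few. Any claim that something is new, unique, unknown or untested is made for them only; others in the source may bear on it.

Measured in a functional assay on MDA-MB-231 cells (Homo sapiens) for antiproliferative activity, read by MTT assay, with a stated time of 72 h; on this read-out lower numbers stand for stronger inhibition and higher numbers for weaker inhibition:
- compound 1 `O=C(CCc1cccc2c1B(O)OC2)Nc1cccc(I)c1`: 5300 nM
- compound 2 `COc1cc(OC)cc(-c2cccc(NC(=O)CCc3cccc4c3B(O)OC4)c2)c1`: 40 nM
- compound 3 `N#Cc1cccc(-c2cccc(NC(=O)CCc3cccc4c3B(O)OC4)c2)c1`: 110 nM

Compound 3 holds the middle position among these three numbers. Its closest neighbour is compound 2, and the gap is a 2.8-fold higher number from compound 2 to compound 3 (0.44 log units; beyond the scatter). Compound 1 lies much further away.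

The next compound, compound 4 `CC(=O)c1cccc(-c2cccc(NC(=O)CCc3cccc4c3B(O)OC4)c2)c1`, has acetyl in place of cyano on an aromatic carbon. The closest guide is a 2.8-fold higher number from compound 2 to compound 3 (0.44 log units; beyond the scatter), which is a modest change between two substituted phenyl groups. The two large steps, a 130-fold lower number from compound 1 to compound 2 (2.12 log units; beyond the scatter) and a 48-fold lower number from compound 1 to compound 3 (1.68 log units; beyond the scatter), both replace iodo. That change does not recur here. Compound 4 keeps a substituted phenyl group. Within the data shown here, no measured step shows this exact exchange, so neither direction is favoured. A change within the scatter, or at most a modest one, is expected in this assay.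

The estimated step is a 1.1-fold lower number from compound 3 to compound 4 (0.04 log units; within the scatter). Compound 4 is expected at 100 nM, with an estimated range of 40 nM to 280 nM.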

Compound 4, half-maximal inhibitory concentration: 52 nM
Compound 4: middle estimate off by 1.9-fold (0.28 log units), on the high side, within the range that was stated.
By their numbers in this assay, from the lowest: compounds 2 and 4 (each within the scatter of the next); then compound 3; then compound 1.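

In this assay, acetyl in place of cyano moves the number beyond the scatter (a 2.1-fold lower number from compound 3 to compound 4 (0.33 log units; beyond the scatter)), so this position responds to an exchange of one small group on the 3-substituted phenyl, not only to the replacement of iodo by a phenyl group. The 3-acetylphenyl group cannot be told apart from the 3,5-dimethoxyphenyl group (a 1.3-fold higher number from compound 2 to compound 4 (0.11 log units; within the scatter)), and in place of iodo it gives a large step (a 100-fold lower number from compound 1 to compound 4 (2.01 log units; beyond the scatter)), so all three substituted phenyl groups shown go far below the iodo compound. Nothing measured here accounts for the difference between acetyl and cyano.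

The compounds shown leave open how an amine, a carboxylic acid or a primary amide would behave on this aromatic carbon. They also leave open whether a longer chain on the carbonyl would keep the number of compound 4.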